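Swapping one ring group on a shared core

The compounds below may be only part of what the source reports. "The series", "measured", "known", "first", "only" and "open" are said of these compounds alone.

In a functional assay on SK-OV-3 cells (Homo sapiens) for cytotoxicity (on this read-out lower numbers stand for stronger inhibition of growth and higher numbers for weaker inhibition of growth), compound 1 `COc1ccc(C2=C(c3cc(OC)c(OC)c(OC)c3)CC3CCCN3C2=O)cc1O` gives > 100000 nM, which is a limit of the assay and not a number. Compound 2 `COc1ccc(C2=C(c3ccc(SC)cc3)CC3CCCN3C2=O)cc1OC(=O)C1CCCN1C(=O)OC(C)(C)C` reads 10000 nM. Compound 3 `COc1ccc(C2=C(c3ccc(SC)cc3)CC3CCCN3C2=O)cc1Br` reads 3000 nM, the lowest number among those measured, and its gap to compound 2 lies beyond the usual scatter.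

Compound 4 `CSc1ccc(C2=C(c3ccc(F)c(C)c3)C(=O)N3CCCC3C2)cc1` has not yet been measured. It carries 4-fluoro-3-methylphenyl in place of 3-bromo-4-methoxyphenyl on a double-bonded ring carbon, (4-fluoro-3-methylphenyl in place of 3-bromo-4-methoxyphenyl on a double-bonded ring carbon). Among the measured compounds shown here, no two measured compounds differ in just one place, so no direct step can guide the expectation. A moderate step towards a higher number, meaning weaker inhibition of growth in this assay, is expected, with compound 3 at 3000 nM as the starting point. The expected size is a 2.7-fold higher number from compound 3 to compound 4 (0.43 log units; beyond the scatter), and this is only an estimate. Compound 4 is expected to read about 8000 nM, with an estimated range of 1500 nM to 40000 nM.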

Compound 4, concentration for 50% growth inhibition: 300 nM
Estimate against measurement, compound 4: 27-fold (1.43 log units) above, outside the stated range (below it).
By their numbers in this assay, from the lowest: compound 4; then compound 3; then compound 2. At a limit, above all of these: compound 1.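

In this assay, the group on the double-bonded ring carbon matters a great deal: putting 4-fluoro-3-methylphenyl in place of 3-bromo-4-methoxyphenyl gives a 10-fold lower number from compound 3 to compound 4 (1.00 log units; beyond the scatter). This is the only pair shown that differs in just one place, so it is the first direct sign that changing this ring group alone, with the rest of the shared core held fixed, can move the number beyond the scatter. Nothing measured here bears on why the number falls with this swap.

Going by these compounds, the two ring groups differ in both of their substituents at once, so it remains open whether the fluoro, the methyl or the loss of the bromo and methoxy groups accounts for the step. Also open, on these data alone, is how this position would respond to a ring carrying an amine or a carboxylic acid, or to a longer chain.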